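Propyl for Phenyl on the Amide Aryl Ring

The compounds below may be only part of what the source reports. "The series", "measured", "known", "first", "only" and "open" are said of these compounds alone.

For the measured compounds named here, compound 2 `O=C(Nc1cccc(-c2oc3cc(-c4ccc(F)cc4)ccc3c(=O)c2O)c1)c1ccc(-c2ccccc2)cc1` is one of only two compounds measured so far in a functional assay on MCF7 cells (Homo sapiens) for antiproliferative activity, read by CCK-8 assay, with a stated time of 72 h (on this read-out lower numbers stand for stronger inhibition and higher numbers for weaker inhibition), where compound 2 gives 38500 nM. The other is compound 1 `Cc1cc(C)cc(C(=O)Nc2cccc(-c3oc4cc(-c5ccc(F)cc5)ccc4c(=O)c3O)c2)c1`, which in this assay gives 20400 nM; the step of a 1.9-fold higher number from compound 1 to compound 2 (0.28 log units; within the scatter) lies within the scatter, so the two numbers cannot be told apart. Compound 3 `CCCc1ccc(C(=O)Nc2cccc(-c3oc4cc(-c5ccc(F)cc5)ccc4c(=O)c3O)c2)cc1` differs from compound 2 by a single change: propyl in place of phenyl on an aromatic carbon. Going by the values given here, the one measured step that touches this part of the molecule is a 1.9-fold higher number from compound 1 to compound 2 (0.28 log units; within the scatter), in which one aromatic group on the carbonyl carbon replaced another and the number moved no further than the scatter allows. Among the compounds with values here, no measured compound carries a propyl group or any chain at this place, so the data give no direction for the new change. Both measured numbers sit in the weak range, and compound 3 is expected to stay there. For compound 3 the estimate in this assay is 30000 nM, with a range from 12000 nM to 80000 nM. This estimate means an expected step of a 1.3-fold lower number from compound 2 to compound 3 (0.11 log units; within the scatter), which is no change beyond the scatter.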

Compound 3, half-maximal inhibitory concentration: 36800 nM
Compound 3: the middle estimate sits 1.2-fold (0.09 log units) below what was measured, within the range that was stated.
By their numbers in this assay, from the lowest: compounds 1, 3 and 2 (each within the scatter of the next).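

In this assay, for the compounds shown here, the earlier compounds had only exchanged one aromatic group on the carbonyl carbon for another, whereas the step of a 1.0-fold lower number from compound 2 to compound 3 (0.02 log units; within the scatter) replaces the terminal phenyl ring with propyl, a chain with no ring, and the number stays within the scatter. The step of a 1.8-fold higher number from compound 1 to compound 3 (0.26 log units; within the scatter) is also within the scatter, so 3,5-dimethylphenyl, 4-phenylphenyl and 4-propylphenyl on the carbonyl carbon cannot be told apart in this set, and an aromatic ring at this aromatic carbon is shown not to be needed for a number of this size. No supporting evidence is available to account for this result.

What the compounds shown leave open is whether any group at this place can move the number beyond the scatter, since all three values lie within the scatter of one another. An amine, a carboxylic acid or a longer chain such as hexyl in place of propyl would test this, and the compounds shown also cannot say whether a change elsewhere on the shared core would matter more.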